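A few compounds are considered here, and "the series" means these few. Any claim that something is new, unique, unknown or untested is made for them only; others in the source may bear on it.

Working notes on the series. Compound 1 `COc1cc(-n2cc(-c3ccc(Cl)cc3)[nH]c2=O)cc(OC)c1OC` carries a chloro on an aromatic carbon of a six-membered aromatic ring of carbon only. In a functional assay on SNB-75 cells (Homo sapiens) for antiproliferative activity (a lower number here means a stronger inhibitor of growth, a higher number a weaker inhibitor of growth), compound 1 gives 25100 nM, the highest of the two numbers in hand. Going by the values given here, its nearest measured neighbour is compound 2 `COc1ccc(-n2cc(-c3ccc(OC)c(OC)c3)[nH]c2=S)cc1Cl`, which in this assay gives 5010 nM; the two structures differ in more than one place, so the pair shows only that compound 2 sits lower, beyond the scatter. Compound 3 `COc1cc(-n2cc(-c3ccccc3)[nH]c2=O)cc(OC)c1OC` is next to be measured in this assay. Relative to compound 1 the change is hydrogen in place of chloro on an aromatic carbon, at a position para to a large group. Among the compounds with values here, no measured pair isolates this change. The step is expected to be small, if anything a modest rise in number. Compound 3 is estimated at 32000 nM with a range from 10000 nM to 90000 nM. The expected step, a 1.3-fold higher number from compound 1 to compound 3 (0.11 log units; within the scatter), is not expected to clear the scatter by much.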

Compound 3, concentration for 50% growth inhibition: 12600 nM
Beside the measured number, compound 3's estimate is 2.5-fold (0.40 log units) above it; measured number inside the range.
By their numbers in this assay, from the lowest: compound 2; then compounds 3 and 1 (each within the scatter of the next).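

Going by these compounds alone, compounds 1 and 3 form the first pair that differ in one place, and so the first direct reading of hydrogen in place of chloro on an aromatic carbon, para to a large group. In this assay the change from 4-chlorophenyl to phenyl gives a 2.0-fold lower number from compound 1 to compound 3 (0.30 log units; within the scatter), so at this position the chloro is not needed to keep the number in this range, and the pair separates the two groups no further. No data in hand give a reason for this step.

Open, as far as these compounds go, is whether an amine or a carboxylic acid at this place would move the number beyond the scatter. Within the data shown here, no single-place pair yet links compound 2 to compound 1 or compound 3, so its several differences from them remain unseparated.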